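The compounds below may be only part of what the source reports. "The series", "measured", "known", "first", "only" and "open" are said of these compounds alone.

Compound 1 `COc1cccc(N2C(=O)COc3ccc(-c4cnc(Cl)c(NS(=O)(=O)c5ccc(F)cc5)c4)cc32)c1`: > 40000 nM
Compound 2 `O=C1COc2ccc(-c3cnc4ccccc4c3)cc2N1c1ccccc1`: > 40000 nM

Both measured compounds were tested in a functional assay on HCT-116 cells (Homo sapiens) for antiproliferative activity, read by MTT assay, with a stated time of 72 h; on this read-out higher numbers stand for weaker inhibition and lower numbers for stronger inhibition. For compound 1 the read-out is a limit of the assay, recorded as > 40000 nM. For compound 2 the read-out is likewise a limit, recorded as > 40000 nM. Both sit at the limit of > 40000 nM in this assay, at which 2 of the 2 values shown sit, so compound 1 stands at the limit itself and no number fixes where it lies beyond it.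

Compound 3 `O=C1COc2ccc(-c3cnc(Cl)c(NS(=O)(=O)c4ccc(F)cc4)c3)cc2N1c1ccc(Cl)cc1` has not been measured. It differs from compound 1 in one place: 4-chlorophenyl in place of 3-methoxyphenyl on an amide-type nitrogen in a ring. Within the data shown here, no measured step between compounds covers this change, and since both recorded values are limits, the data give no direction for it. In this assay the expected step is a number no higher from compound 1 to compound 3 (the limit leaves the size open), none beyond the scatter. Compound 3 is therefore estimated at 40000 nM, with a range from 15000 nM to 80000 nM, and a limit remains the most likely outcome.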

Compound 3, half-maximal inhibitory concentration: 27900 nM
Compound 3: the middle estimate sits 1.4-fold (0.16 log units) above what was measured; the measured number falls inside the stated range.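

In this assay, compound 3 is the only one of the three compounds shown whose value is not a limit, so a read-out can be obtained with 4-chlorophenyl on the amide-type nitrogen in a ring. Putting 4-chlorophenyl in place of 3-methoxyphenyl at this position gives an at least 1.4-fold lower number from compound 1 to compound 3 (0.15 log units; that floor lies within the scatter). Because compound 1 holds a limit, that step is only a floor and its true size stays unknown: the limit of > 40000 nM in this assay, at which 2 of the 3 values shown sit.

From the compounds shown here alone, what a 3-chlorophenyl or a 4-methoxyphenyl group would give at this position remains open, so the data do not separate the identity of the substituent from its place on the phenyl ring. Also open, going by these compounds, is the effect of an amine or a carboxylic acid on that phenyl ring.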